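From a Carboxymethoxy Group to an Aminoamino Group

The source may report more compounds than this note shows. Statements on the series, on what has been measured and on what is new or still open speak of the compounds shown alone.

Compound 1 `CC(C)(C)OC(=O)C(=O)Nc1cccccc1=O`: 82%
Compound 2 `O=C(O)C(=O)Nc1cccccc1=O`: 62%; 68%; 73% (3 entries)
Compound 3 `O=C(O)COC(=O)C(=O)Nc1cccccc1=O`: 50%

Three compounds with a shared core were tested in a functional assay on the whole organism (strain Sprague-Dawley CD) for inhibition, with Rattus norvegicus as the target, read by paw edema, at a dose of 100 mg/kg by the oral route; a lower number here means a weaker effect, a higher number a stronger effect of the compound at the dose given. Compound 1 gives 82%, compound 2 gives 62%; 68%; 73% (3 entries), and compound 3 gives 50%. Among the single numbers, compound 3 stands lowest; its nearest neighbour is compound 1, and the only measured step, a number 32 percentage points lower from compound 1 to compound 3 (beyond the scatter), is a large one. The repeated entries of compound 2 the several entries of compound 2 in this assay, 62%; 68%; 73% (3 entries) show how far single readings of this kind can move.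

The next compound, compound 4 `NNC(=O)C(=O)Nc1cccccc1=O`, is reached from compound 3 by one change: aminoamino in place of carboxymethoxy on a carbonyl carbon. Among the measured compounds shown here, no measured step involves an aminoamino group, so the one step on record, from an oxygen bearing tert-butyl to one bearing carboxymethyl, bears on this change only loosely: it shows that the group on this carbonyl carbon can move the read-out in this assay by a large amount. The change from carboxymethoxy to aminoamino removes the group that accompanied the lowest number, and compound 2, which lacks any such group, sits higher than compound 3.

Compound 4 is therefore expected to rise, by a step of a number 12 percentage points higher from compound 3 to compound 4 (beyond the scatter), to an estimated 62%, within a range from 35% to 85%.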

Compound 4, a percentage reported as inhibition, in the whole organism at one dose (the size of the read-out at that dose, not a potency): 78%
The estimate for compound 4 lay 16 percentage points below the measured number; measured number inside the range.
By their numbers in this assay, from the lowest: compound 3; then compounds 4 and 1 (each within the scatter of the next).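

In this assay, replacing carboxymethoxy with aminoamino on a carbonyl carbon gives a number 28 percentage points higher from compound 3 to compound 4 (beyond the scatter). Among the compounds shown here, this shows that the read-out at this position can rise as well as fall, whereas the only step available before ran downward. Set against tert-butoxy, the same aminoamino group gives a number 4 percentage points lower from compound 1 to compound 4 (within the scatter), so two groups with quite different atoms sit level here and, among the groups compared in single steps, carboxymethoxy alone stands apart with the lower number. That small gap should not be read as an order, as repeated readings of one compound in this assay spread further: the several entries of compound 2 in this assay, 62%; 68%; 73% (3 entries)

The compounds shown leave open whether the terminal amino part of aminoamino matters, which a plain amine or a methylamine on the same carbonyl carbon would address, and whether a longer chain ending in an amine or a carboxylic acid would behave like aminoamino or like carboxymethoxy. They also show only a stronger or weaker effect at a single oral dose and leave open how these groups would compare at other doses.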